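This account rests on a few compounds, and the source may have more. Where it says the series, first, only, none or still open, it means among the compounds named here.

Measured in a functional assay on HCT-116 cells (Homo sapiens) for inhibition, read by MTT assay, with a stated time of 48 h; on this read-out lower numbers stand for stronger inhibition and higher numbers for weaker inhibition:
- compound 1 `COCC(=O)N(Cc1ccc(OC)c(O)c1)c1cc(OC)c(OC)c(OC)c1`: 230 nM
- compound 2 `C/C=C/C(=O)N(Cc1ccc(OC)c(N)c1)c1cc(OC)c(OC)c(OC)c1`: 300 nM
- compound 3 `COc1cc(NCc2ccc(Br)cc2)cc(OC)c1OC`: > 80000 nM

Among the compounds with values here, only two of these readings are numbers, and compound 1 at 230 nM lies within the usual scatter of compound 2 at 300 nM. For compound 3, > 80000 nM is a limit of the assay.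

Compound 4 `CC/C=C/C(=O)N(Cc1ccc(OC)c(O)c1)c1cc(OC)c(OC)c(OC)c1` has but-1-en-1-yl in place of methoxymethyl on a carbonyl carbon. Within the data shown here, no measured step covers this change, so in this assay the expectation is a small move towards higher numbers, hardly beyond the scatter. The estimated step is a 1.5-fold higher number from compound 1 to compound 4 (0.18 log units; within the scatter). For compound 4 the expected value is 350 nM, with an estimated range of 100 nM to 1200 nM.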

Compound 4, half-maximal inhibitory concentration: 63 nM
Beside the measured number, compound 4's estimate is 5.6-fold (0.74 log units) above it, and the stated range ends above it.
By their numbers in this assay, from the lowest: compound 4; then compounds 1 and 2 (each within the scatter of the next). At a limit, above all of these: compound 3.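

In this assay, but-1-en-1-yl in place of methoxymethyl on a carbonyl carbon gives a 3.7-fold lower number from compound 1 to compound 4 (0.56 log units; beyond the scatter), the only step shown at this place and one beyond the scatter. The earlier compounds shown here differed in more than one place and could not show that the group on this carbonyl carbon alone moves the reading. Nothing measured here explains the step. From the compounds shown here alone, whether the double bond or the chain length carries it stays open, as does what a saturated butyl chain, a longer chain or an amine would give at this place.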